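The source may hold more compounds than are shown below. What is called first, only, known or untested is meant among the compounds shown, and "the series" means these compounds.

The compounds here share one core: an unsaturated ketone linking two aromatic rings, each ring carrying its own substituents. Compound 1 (`COc1ccc(/C=C/C(=O)c2ccc(N)c(-c3ccc(F)cc3)c2)cc1`) was measured in an assay on A549 cells for inhibition of transcription factor p65 (Homo sapiens), read by fluorescence, with a stated time of 2 h (a lower number here means a stronger inhibitor, a higher number a weaker inhibitor), and gives > 50000 nM, which is a limit of the assay rather than a number. Compound 2 (`COc1cc(/C=C/C(=O)c2cccc(-c3cccc(F)c3)c2)ccc1O`) carries a hydroxy and a methoxy group on its terminal ring and gives 12900 nM in this assay. Compound 3 (`COc1cccc(/C=C/C(=O)c2cccc(-c3cccc(F)c3)c2)c1OC`), carrying two methoxy groups, gives 24100 nM in this assay, and the gap between compound 2 and compound 3 lies within the usual scatter, so the two cannot be told apart on these numbers.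

Compound 4 (`COc1ccc(/C=C/C(=O)c2cccc(-c3cccc(F)c3)c2)cc1OC`) has not yet been measured. It differs from compound 2 in one place: methyl in place of hydrogen on an oxygen on an aromatic ring, which turns a hydroxy into a methoxy. For the measured compounds named here, no measured pair in this set isolates that change. Because compound 3 with both oxygens methylated gives 24100 nM, the expected step in this assay is none beyond the scatter, or a slight weakening. Compound 4 is therefore expected to give 20000 nM, with a range from 8000 nM to 50000 nM. That expected shift amounts to a 1.6-fold higher number from compound 2 to compound 4 (0.19 log units; within the scatter).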

Compound 4, half-maximal inhibitory concentration: 33400 nM
Estimate against measurement, compound 4: 1.7-fold (0.22 log units) below; the range from low to high includes it.
By their numbers in this assay, from the lowest: compounds 2, 3 and 4 (each within the scatter of the next, the first and the last beyond it). At a limit, above all of these: compound 1.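

For the compounds shown here, this is the first comparison in the set that isolates a single change: turning the hydroxy of compound 2 into the methoxy of compound 4 gives a 2.6-fold higher number from compound 2 to compound 4 (0.41 log units; beyond the scatter) in this assay. Going by these compounds alone, the step is modest but real, so at this oxygen on the aromatic ring, methyl in place of hydrogen makes the inhibitor weaker, which the earlier compounds could not show. Compound 4 still gives a true number rather than a limit, so the size of the step can be read, and the one limit in the set is this: the limit of > 50000 nM in this assay, at which 1 of the 4 values shown sits.

This single pair cannot show whether the same step would hold with other substituents elsewhere on the shared core. Nor does it show what an ethyl chain on this oxygen, or an amine in place of the hydroxy, would do.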